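Swapping the aryl group on a shared core

The source may hold more compounds than are shown below. What is called first, only, known or untested is meant among the compounds shown, and "the series" means these compounds.

Measured compounds:
compound 1, `O=C1COc2ccc(-c3[nH]c(-c4c[nH]c5ncccc45)nc3-c3ccccc3)cc2N1`: 111%
compound 2, `O=C1COc2ccc(-c3[nH]c(-c4ccc(C(F)(F)F)cc4)nc3-c3ccccc3)cc2N1`: 111%
compound 3, `O=C1COc2ccc(-c3[nH]c(-c4ccc(F)cc4)nc3-c3ccccc3)cc2N1`: 108%

All three were read in a functional assay on MV4-11 cells (Homo sapiens) for cytotoxicity, read by colorimetric assay and MTT assay, with a stated time of 3 days, tested at 1 uM (a higher number here means a weaker effect of the compound at the concentration tested, a lower number a stronger effect), and none of them shows a marked effect at the concentration tested. Compound 3 has the lowest of the three numbers, but its gaps to the other two, a number 3 percentage points lower from compound 1 to compound 3 (within the scatter) and a number 3 percentage points lower from compound 2 to compound 3 (within the scatter), both lie within the scatter, so no order can be read among compound 1, compound 2 and compound 3.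

Compound 4, `O=C1COc2ccc(-c3[nH]c(-c4ccc(Cl)cc4Cl)nc3-c3ccccc3)cc2N1`, differs from compound 3 by 2,4-dichlorophenyl in place of 4-fluorophenyl on an aromatic carbon. For the measured compounds named here, the steps that bear on this change are those that exchange the group on the same aromatic carbon of the five-membered aromatic ring with 2 nitrogen: a number 3 percentage points lower from compound 1 to compound 3 (within the scatter), a number 3 percentage points lower from compound 2 to compound 3 (within the scatter) and no change at the digits printed from compound 1 to compound 2 (within the scatter). Each of them was within the scatter, although the groups exchanged ranged widely in size and kind. The step to the 2,4-dichlorophenyl group is therefore expected to be of the same sort, a number 1 percentage points lower from compound 3 to compound 4 (within the scatter), with no movement beyond the scatter in this assay . Compound 4 is accordingly estimated at 107%, with a range from 95% to 118%.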

Compound 4, a percentage reported as activity, at one concentration (the size of the read-out at that concentration, not a potency): 109%
Beside the measured number, compound 4's estimate is 2 percentage points below it; the range from low to high includes it.
By their numbers in this assay, from the lowest: compounds 3, 4, 1 and 2 (each within the scatter of the next).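

In this assay, for the compounds shown here, the 2,4-dichlorophenyl group brings chlorine to this position for the first time, yet the read-out holds: a number 1 percentage points higher from compound 3 to compound 4 (within the scatter), a number 2 percentage points lower from compound 2 to compound 4 (within the scatter) and a number 2 percentage points lower from compound 1 to compound 4 (within the scatter). The position between two ring nitrogen atoms thus tolerates an aryl group with a second ring substituent as well, and no order can be read among the four compounds, none of which shows a marked effect at the concentration tested. No measurement at hand bears on this flat result.

Every group shown at this position is aromatic, so it stays open whether an amine, a carboxylic acid or a longer alkyl chain there would move the number. Also open, on these data alone, is whether changing the phenyl group elsewhere on the shared core would do so.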